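Swapping azido for amino in compound 2

The compounds below may be only part of what the source reports. "The series", "measured", "known", "first", "only" and "open" are said of these compounds alone.

Measured so far in a functional assay on KYSE-450 cells (Homo sapiens) for inhibition, read by CCK-8 assay, with a stated time of 48 h; on this read-out lower numbers stand for stronger inhibition and higher numbers for weaker inhibition:
- compound 1 `COc1ccc(CN(C(=O)CSC(=S)N2CCN(C(=O)OC(C)(C)C)CC2)c2cc(OC)c(OC)c(OC)c2)cc1` gives 250 nM as its value
- compound 2 `COc1ccc(CN(C(=O)CSC(=S)N2CCN(C(=O)OC(C)(C)C)CC2)c2cc(OC)c(OC)c(OC)c2)cc1N=[N+]=[N-]` gives 840 nM as its value

For the measured compounds named here, of these two numbers, the one for compound 2 is the higher, so compound 2 is the weaker inhibitor of the pair. Compound 3 `COc1ccc(CN(C(=O)CSC(=S)N2CCN(C(=O)OC(C)(C)C)CC2)c2cc(OC)c(OC)c(OC)c2)cc1N` differs from compound 2 in one place, ortho to a methoxy group (amino in place of azido on an aromatic carbon).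

Going by the values given here, only one measured step bears on this change. It is a 3.4-fold higher number from compound 1 to compound 2 (0.53 log units; beyond the scatter) and came from putting azido in place of hydrogen on that same carbon. Compound 3 no longer carries the azido group, so a move back toward compound 1 (250 nM) seems likely. Among the compounds with values here, no measured compound carries an amino group, however, so this remains uncertain. Within the data shown here, the expected change is a 2.6-fold lower number from compound 2 to compound 3 (0.42 log units; beyond the scatter) in this assay and would be of modest size, similar to the one measured step. The estimated value for compound 3 is 320 nM (expected range 100 nM to 800 nM).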

Compound 3, half-maximal inhibitory concentration: 208 nM
The estimate for compound 3 lay 1.5-fold (0.19 log units) above the measured number; the measured number falls inside the stated range.
By their numbers in this assay, from the lowest: compounds 3 and 1 (each within the scatter of the next); then compound 2.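

In this assay, the change from azido to amino on this aromatic carbon gives a 4.0-fold lower number from compound 2 to compound 3 (0.61 log units; beyond the scatter) and so removes the loss seen with azido, which shows that this loss does not extend to every nitrogen-linked group placed here. Compared with hydrogen on the same carbon, the amino group gives a 1.2-fold lower number from compound 1 to compound 3 (0.08 log units; within the scatter) and this step lies within the usual scatter, so compound 1 and compound 3 cannot be told apart on this read-out, and of the three groups seen at this position only azido stands apart. Nothing in the available data explains why azido and amino differ in this way.

The compounds shown leave open how far this acceptance of the amino group reaches, since an acetamide, a dimethylamino group or a hydroxyl group on this carbon could each behave like amino or like azido. They also leave open whether the change from azido to amino would give a step of similar size on a different carbon of the same ring, or with another group in place of the neighbouring methoxy group.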